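Aryl sulfonyl substituent changes in a receptor binding series

The source may hold more compounds than are shown below. What is called first, only, known or untested is meant among the compounds shown, and "the series" means these compounds.

compound 1 `CC1CCN(c2c(S(=O)(=O)c3cccc(Cl)c3)cnc3cc(Cl)ccc23)CC1`: 92%
compound 2 `CC1CCN(c2c(S(=O)(=O)c3ccc(C#N)cc3)cnc3cc(Cl)ccc23)CC1`: 70%

In an assay on isolated protein for displacement of a labelled ligand from metabotropic glutamate receptor 5 (Homo sapiens), with a stated time of 60 min, tested at 1 uM (on this read-out higher numbers stand for more inhibition at the one concentration tested (going by the name of the read-out) and lower numbers for less inhibition), compound 2 gives 70%, the lower of the two numbers shown; compound 1 stands above it, a number 22 percentage points lower from compound 1 to compound 2 (beyond the scatter). Compound 3 `Cc1ccc(S(=O)(=O)c2cnc3cc(Cl)ccc3c2N2CCC(C)CC2)cc1` differs from compound 2 by methyl in place of cyano on an aromatic carbon. Within the data shown here, no measured step swaps cyano for methyl. Among the measured compounds shown here, the one step at hand, a number 22 percentage points lower from compound 1 to compound 2 (beyond the scatter), changes the aryl group on the sulfonyl sulfur and shows that such a change can move this assay beyond the scatter. For the measured compounds named here, with no closer precedent, a move back toward the level of compound 1 is plausible but uncertain. Compound 3 is expected at 80% (range 60% to 95%), an expected step of a number 10 percentage points higher from compound 2 to compound 3 (within the scatter).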

Compound 3, a percentage reported as inhibition, at one concentration (the size of the read-out at that concentration, not a potency): 94%
The estimate for compound 3 lay 14 percentage points below the measured number, within the range that was stated.
By their numbers in this assay, from the lowest: compound 2; then compounds 1 and 3 (each within the scatter of the next).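

In this assay the change from 4-cyanophenyl to 4-methylphenyl gives a number 24 percentage points higher from compound 2 to compound 3 (beyond the scatter) and shows that the lower number of compound 2 does not extend to every group on this aromatic carbon. The 3-chlorophenyl and 4-methylphenyl groups cannot be told apart on this read-out, with a number 2 percentage points higher from compound 1 to compound 3 (within the scatter) as their step. Nothing available explains the gap between cyano and methyl.

Open, from the compounds shown here alone, is whether an amine, a carboxylic acid or a methoxy group on this aromatic carbon would stay with methyl or with cyano. A single concentration also leaves compound 1 and compound 3 unranked in potency.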